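A few compounds are considered here, and "the series" means these few. Any claim that something is new, unique, unknown or untested is made for them only; others in the source may bear on it.

Of the compounds shown here, three from this series have been measured in a functional assay on HT-29 cells (Homo sapiens) for inhibition, read by sulforhodamine B assay, with a stated time of 48 h; a lower number here means a stronger inhibitor of growth, a higher number a weaker inhibitor of growth. Compound 1 `COc1cc(-c2cc(/C=C/C(=O)c3ccc(N)cc3)[nH]n2)cc(OC)c1OC` gives 1850 nM. Compound 2 `COc1ccc(C(=O)/C=C/c2cc(-c3cc(OC)c(OC)c(OC)c3)n[nH]2)cc1` gives 1970 nM, and compound 3 `COc1cc(C(=O)/C=C/c2cc(-c3cc(OC)c(OC)c(OC)c3)n[nH]2)cc(OC)c1OC` gives 1790 nM. Compound 2 has the highest of these three numbers, yet its gaps to compound 1 and to compound 3 both lie within the scatter, so the three stand level for practical purposes. Among the compounds with values here, the one change followed as a single step is a 1.1-fold higher number from compound 1 to compound 2 (0.03 log units; within the scatter).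

Within the data shown here, compound 4 `COc1cc(-c2cc(/C=C/C(=O)c3ccc(F)c(F)c3)[nH]n2)cc(OC)c1OC` is the next compound to be measured. 3,4-difluorophenyl in place of 4-methoxyphenyl on a carbonyl carbon No measured step bears directly on this kind of change: the only recorded step is of another kind and stayed within the scatter, and no measured compound carries a fluorine. The expectation therefore rests on how little the numbers have moved so far, and the expected step is a 1.0-fold higher number from compound 2 to compound 4 (0.01 log units; within the scatter), none beyond the scatter. Compound 4 is expected to give about 2000 nM, with a range from 700 nM to 6000 nM.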

Compound 4, concentration for 50% growth inhibition: 2620 nM
For compound 4 the middle estimate is 1.3-fold (0.12 log units) below the measured one, and the stated range covers the measured number.
By their numbers in this assay, from the lowest: compounds 3, 1, 2 and 4 (each within the scatter of the next).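

Within the data shown here, on the carbonyl carbon, the aryl group tolerates a wider swap than the earlier compounds showed. In this assay, 3,4-difluorophenyl in place of 4-methoxyphenyl gives only a small step (a 1.3-fold higher number from compound 2 to compound 4 (0.12 log units; within the scatter)), and 3,4-difluorophenyl in place of 4-aminophenyl also stays small (a 1.4-fold higher number from compound 1 to compound 4 (0.15 log units; within the scatter)), so a ring bearing two fluorines stands level with rings bearing a methoxy or an amino group. No measured evidence shown here offers an explanation for these small steps.

The compounds shown cannot separate the effect of each fluorine, since 4-fluorophenyl is not among them. They also leave open whether this position would stay as forgiving with a non-aromatic group on the carbonyl carbon, such as a cyclohexyl ring, or with a carboxylic acid on the aryl ring.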